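Sulfonamide aryl swaps on a methoxyphenyl-piperazine series

A few compounds are considered here, and "the series" means these few. Any claim that something is new, unique, unknown or untested is made for them only; others in the source may bear on it.

Measured so far in an assay on isolated protein for binding affinity to 5-hydroxytryptamine receptor 6 (Homo sapiens); on this read-out lower numbers stand for stronger inhibition and higher numbers for weaker inhibition:
compound 1, `COc1ccc(S(=O)(=O)Nc2cc(Br)cc(Br)c2)cc1N1CCNCC1`: 0.501 nM
compound 2, `COc1ccc(Cl)cc1NS(=O)(=O)c1ccc(OC)c(N2CCNCC2)c1`: 1.26 nM

Compound 2 holds the higher of the two numbers. Within the data shown here, its only neighbour is compound 1, and the one measured step, a 2.5-fold higher number from compound 1 to compound 2 (0.40 log units; beyond the scatter), separates them; it went with exchange of a dihalogenated phenyl for one carrying methoxy and a single chlorine.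

Compound 3, `COc1ccc(S(=O)(=O)Nc2cc(Br)cc(Cl)c2Cl)cc1N1CCNCC1`, differs from compound 2 in one place: 5-bromo-2,3-dichlorophenyl in place of 5-chloro-2-methoxyphenyl on a sulfonamide nitrogen. The change undoes the direction of that single step, returning to a phenyl bearing three halogens and no hydrogen-bond acceptor, which the pair of compound 1 and compound 2 links to the lower number. On that basis compound 3 is expected to move back down by about the size of the measured step, a 2.1-fold lower number from compound 2 to compound 3 (0.32 log units; beyond the scatter). The estimate for compound 3 in this assay is 0.6 nM, with a range from 0.2 nM to 2 nM.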

Compound 3, inhibition constant: 3.98 nM
Compound 3: the middle estimate sits 6.6-fold (0.82 log units) below what was measured; the measured number lies above the stated range.
By their numbers in this assay, from the lowest: compound 1; then compound 2; then compound 3.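

In this assay, a phenyl carrying only halogens on the sulfonamide nitrogen does not by itself go with the lower number, as the exchange for 5-bromo-2,3-dichlorophenyl gives a 3.2-fold higher number from compound 2 to compound 3 (0.50 log units; beyond the scatter) and leaves compound 3 above compound 2, which keeps its methoxy group. The two halogen-only phenyls also stand apart, with a 7.9-fold higher number from compound 1 to compound 3 (0.90 log units; beyond the scatter) on going from 3,5-dibromophenyl to 5-bromo-2,3-dichlorophenyl, so at this place the number depends on which halogens the phenyl carries and how they are arranged, not on halogen alone. Nothing available explains this rise in the number.

Which of the three halogens in 5-bromo-2,3-dichlorophenyl goes with the rise remains open. Also open, as far as these compounds go, is how a phenyl carrying a nitrile or a carboxylic acid would read at this sulfonamide nitrogen.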